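Adding a Methoxy Group to a Dimethoxyphenyl Triazole

The source may report more compounds than this note shows. Statements on the series, on what has been measured and on what is new or still open speak of the compounds shown alone.

Measured compounds:
compound 1, `COc1cc(-c2nnc(SCC(=O)Nc3ccc(/C(C)=N/O)cc3)n2-c2ccccc2)cc(OC)c1OC`, 70%
compound 2, `CCn1c(SCC(=O)Nc2ccc(/C(C)=N/O)cc2)nnc1-c1ccc(OC)c(OC)c1`, 73%

Of the compounds shown here, two have been tested in a functional assay on the whole organism (strain albino) for inhibition, with Rattus norvegicus as the target, read by paw edema, with stated times of 30 min and 5 h, at a dose of 0.28 mmol/kg by the oral route; on this read-out lower numbers stand for less inhibition and higher numbers for more inhibition at the one dose given (going by the name of the read-out). In this assay compound 1 gives 70%, and compound 2 gives 73%. On the numbers shown, compound 2 stands at the top of the two, yet compound 1 lies within the usual scatter of it, so the two cannot be told apart, and no step between them can be stated beyond that.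

Compound 3, `CCn1c(SCC(=O)Nc2ccc(/C(C)=N/O)cc2)nnc1-c1cc(OC)c(OC)c(OC)c1`, has not yet been measured. It differs from compound 2 in one place: methoxy in place of hydrogen on an aromatic carbon. The new methoxy group sits on an aromatic carbon of a six-membered aromatic ring of carbon only, ortho to a methoxy group and meta to a methoxy group and to a large group.

Nothing measured here shows what such a change does on its own. Compound 1 carries the same three methoxy groups on the corresponding ring and gives 70%, a number indistinguishable from that of compound 2. The change is therefore expected to produce a step of a number 2 percentage points lower from compound 2 to compound 3 (within the scatter), none beyond the scatter. Compound 3 is estimated to give 71%, expected between 60% and 82%.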

Compound 3, a percentage reported as inhibition, in the whole organism at one dose (the size of the read-out at that dose, not a potency): 61%
The estimate for compound 3 lay 10 percentage points above the measured number; measured number inside the range.
By their numbers in this assay, from the lowest: compounds 3, 1 and 2 (each within the scatter of the next, the first and the last beyond it).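

In this assay, methoxy in place of hydrogen on this aromatic carbon, ortho to a methoxy group, gives a number 12 percentage points lower from compound 2 to compound 3 (beyond the scatter), the first step among these compounds that clears the usual scatter, though it is a modest one. At this position, then, the added methoxy group is not neutral when ethyl sits on the aromatic nitrogen. Ethyl in place of phenyl on that nitrogen gives a number 9 percentage points lower from compound 1 to compound 3 (within the scatter), and because that step stays within the scatter, the change cannot be told apart from no change; nothing shown here gives a measured reason for either step.

What the compounds leave open is whether the step belongs to methoxy itself or would also appear with another group at this carbon, such as a hydroxyl group, a fluorine atom or an amine. A compound with phenyl on the aromatic nitrogen and hydrogen at this carbon would show whether the same methoxy change gives a similar step when phenyl replaces ethyl.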